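The compounds below may be only part of what the source reports. "The series", "measured", "known", "first", "only" and "open" are said of these compounds alone.

Compound 2 `CN(c1ccc2[nH]c(-c3n[nH]c4ccccc34)cc2n1)S(=O)(=O)c1ccccc1` is the lower of the two compounds measured in a functional assay on KB cells (Homo sapiens) for antiproliferative activity, read by MTT assay, with a stated time of 72 h; on this read-out lower numbers stand for stronger inhibition and higher numbers for weaker inhibition: compound 2 gives 2400 nM, while compound 1 `CCC(=O)N(C)c1ccc2[nH]c(-c3n[nH]c4ccccc34)cc2n1` gives 9300 nM, and the step of a 3.9-fold lower number from compound 1 to compound 2 (0.59 log units; beyond the scatter). Compound 3 `COc1ccc(S(=O)(=O)N(C)c2ccc3[nH]c(-c4n[nH]c5ccccc45)cc3n2)cc1OC` differs from compound 2 by 3,4-dimethoxyphenyl in place of phenyl on a sulfonyl sulfur. Going by the values given here, the only measured step changes the group on the sulfonamide nitrogen, not the aryl on the sulfonyl sulfur, so it bears only loosely on this change. A small step, or none beyond the scatter, is therefore expected, a 1.5-fold lower number from compound 2 to compound 3 (0.18 log units; within the scatter). For compound 3 the estimated value in this assay is 1600 nM, in a range from 500 nM to 5000 nM.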

Compound 3, half-maximal inhibitory concentration: 10100 nM
For compound 3 the middle estimate is 6.3-fold (0.80 log units) below the measured one, and the stated range ends below it.
By their numbers in this assay, from the lowest: compound 2; then compounds 1 and 3 (each within the scatter of the next).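

In this assay, the aryl group on the sulfonyl sulfur proves not to be a neutral site: 3,4-dimethoxyphenyl in place of phenyl gives a 4.2-fold higher number from compound 2 to compound 3 (0.62 log units; beyond the scatter), a change towards weaker inhibition. Nothing shown accounts for this step. The compounds shown leave open whether one methoxy group alone would produce the same step, or whether both are needed. They also leave open how a phenyl carrying a fluorine, an amine or a carboxylic acid would behave on the sulfonyl sulfur.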